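The source may hold more compounds than are shown below. What is called first, only, known or untested is meant among the compounds shown, and "the series" means these compounds.

Measured compounds:
- compound 1, `Fc1ccc(C2(c3ccc(F)cc3)CNC(c3ccccc3)=N2)cc1`, in an assay on LM cells for displacement of a labelled ligand from Neuropeptide Y receptor type 5 (Homo sapiens) (on this read-out higher numbers stand for weaker inhibition and lower numbers for stronger inhibition), compound 1 gives 32 nM
- compound 2, `Nc1cccc(C2=NC(c3ccc(F)cc3)(c3ccc(F)cc3)CN2)c1`, in this assay compound 2 gives 300 nM

For the measured compounds named here, compound 2 carries the higher of the two numbers seen so far, and the only neighbour is compound 1, with a 9.4-fold higher number from compound 1 to compound 2 (0.97 log units; beyond the scatter) separating them. The two differ only in that compound 2 bears an amino group on an aromatic carbon where compound 1 has hydrogen.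

Compound 3, `Fc1ccc(C2(c3ccc(F)cc3)CNC(c3ccccn3)=N2)cc1`, has not yet been measured. Its change from compound 2 is pyridin-2-yl in place of 3-aminophenyl on a carbon with a double bond to nitrogen. In effect the amino group leaves again, and at the same time the plain benzene ring gives way to a pyridine ring, which was not tried in the measured pair.

Going by the values given here, only one measured step bears on this: a 9.4-fold higher number from compound 1 to compound 2 (0.97 log units; beyond the scatter), which shows that adding the amino group weakened binding. From the compounds shown here alone, removing it should reverse part or all of that, so compound 3 is expected to show a 6.0-fold lower number from compound 2 to compound 3 (0.78 log units; beyond the scatter); the effect of the pyridine ring on its own is unknown, which widens the range. Compound 3 is therefore estimated at 50 nM, with a range from 15 nM to 200 nM.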

Compound 3, half-maximal inhibitory concentration: 160 nM
Beside the measured number, compound 3's estimate is 3.2-fold (0.51 log units) below it; measured number inside the range.
By their numbers in this assay, from the lowest: compound 1; then compounds 3 and 2 (each within the scatter of the next).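

In this assay, pyridin-2-yl in place of phenyl on the carbon with a double bond to nitrogen gives a 5.0-fold higher number from compound 1 to compound 3 (0.70 log units; beyond the scatter), so a ring nitrogen alone, with no amino group present, is enough to move the number clearly away from that of compound 1. Compound 1 therefore keeps the lowest number, and both replacements of its phenyl group, 3-aminophenyl and pyridin-2-yl, go the same way, although only these three compounds support that pattern. The result also gives a 1.9-fold lower number from compound 2 to compound 3 (0.27 log units; within the scatter), so this assay cannot tell 3-aminophenyl and pyridin-2-yl apart at this place, even though the first has a hydrogen-bond donor and the second has none, and nothing available here explains either step.

From the compounds shown here alone, it remains open whether the ring nitrogen's location matters, which pyridin-3-yl or pyridin-4-yl at the same place would address. Also open, going by these compounds, is whether a small group such as methyl or fluoro on the phenyl ring, or a saturated ring such as cyclohexyl in its stead, would keep the number close to that of compound 1.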